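A para substituent swap on the shared core

The source may hold more compounds than are shown below. What is called first, only, known or untested is meant among the compounds shown, and "the series" means these compounds.

Compound 3, `CNc1nc(NCc2ccc(NS(C)(=O)=O)cc2)cc(-c2ccccn2)n1`, is the most active of the three measured compounds in a functional assay on HEK293 cells for agonist activity at G-protein coupled receptor 39 (Mus musculus), read by inositol phosphate accumulation (on this read-out higher numbers stand for an effect only at larger amounts of compound and lower numbers for an effect already at smaller amounts), where compound 3 gives 8 nM. Compound 2, `CNc1nc(NCc2ccc(S(C)(=O)=O)cc2)cc(-c2ccccn2)n1`, gives 185 nM in this assay, and compound 1, `CNc1nc(NCc2ccc(N(C)C(C)=O)cc2)cc(-c2ccccn2)n1`, gives 2610 nM. The step of a 23-fold lower number from compound 2 to compound 3 (1.36 log units; beyond the scatter) and the step of a 330-fold lower number from compound 1 to compound 3 (2.51 log units; beyond the scatter) both show the methanesulfonamido group going with the lowest number by a wide margin, and the step of a 14-fold lower number from compound 1 to compound 2 (1.15 log units; beyond the scatter) separates the other two.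

Compound 4, `CNc1nc(NCc2ccc(OC(F)(F)F)cc2)cc(-c2ccccn2)n1`, differs from compound 3 in one place: trifluoromethoxy in place of methanesulfonamido on an aromatic carbon. Among the compounds with values here, no measured step matches this exact change, so the nearest guidance comes from the two steps into compound 3, which were large and in the same direction, and from the fact that every replacement of the methanesulfonamido group seen so far sat well above compound 3. He therefore expects the move from compound 3 to compound 4 to be a sizeable loss, roughly a 50-fold higher number from compound 3 to compound 4 (1.70 log units; beyond the scatter), landing compound 4 somewhere between compound 2 and compound 1. He estimates that compound 4 will give 400 nM in this assay, with a plausible range from 80 nM to 2500 nM.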

Compound 4, half-maximal effective concentration: 7 nM
The estimate for compound 4 lay 57-fold (1.76 log units) above the measured number; measured number outside the range, below it.
By their numbers in this assay, from the lowest: compounds 4 and 3 (each within the scatter of the next); then compound 2; then compound 1.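

The step of a 1.1-fold lower number from compound 3 to compound 4 (0.06 log units; within the scatter) in this assay shows that a low number on this aromatic carbon, para to a large group, does not depend on the methanesulfonamido group: the trifluoromethoxy group that replaces it has 0 hydrogen-bond donors and 1 hydrogen-bond acceptor, against 1 hydrogen-bond donor and 2 hydrogen-bond acceptors in the group that leaves, yet the two numbers stay within the scatter. Until now, only the methanesulfonamido group had reached this low level, but the step of a 26-fold lower number from compound 2 to compound 4 (1.42 log units; beyond the scatter) and the step of a 370-fold lower number from compound 1 to compound 4 (2.57 log units; beyond the scatter) are both large and show that the trifluoromethoxy group also stands well clear of the methylsulfonyl and acetyl(methyl)amino groups. No measurement is available that would explain how two such differently built groups come to read alike here.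

The compounds shown leave open how a trifluoromethyl group, a chlorine atom, a primary amine or a carboxylic acid would read at this place on the shared core. They also leave open whether the match between compound 3 and compound 4 would hold with a longer chain on the oxygen or the sulfur.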